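Hexyloxy to ethylamino at the carbonyl: compound 3 to 4

This account rests on a few compounds, and the source may have more. Where it says the series, first, only, none or still open, it means among the compounds named here.

Measured compounds:
Compound 1 `CCOc1ccc(-c2cccc(S(=O)(=O)N(C)C)c2)cc1` – in an assay on COS-7 cells for inhibition of patatin-like phospholipase domain-containing protein 2 (Mus musculus) (a higher number here means a weaker inhibitor, a lower number a stronger inhibitor), compound 1 gives 110000 nM.
Compound 2 `CCOc1ccc(-c2ccccc2)cc1` – compound 2 gives only a limit of the assay, > 200000 nM.
Compound 3 `CCCCCCOC(=O)c1cccc(-c2ccc(OCC)cc2)c1` – compound 3 likewise gives only a limit, > 200000 nM.

Compound 3 thus stands at the limit of > 200000 nM in this assay, at which 2 of the 3 values shown sit, with no number of its own. The step to compound 4 `CCNC(=O)c1cccc(-c2ccc(OCC)cc2)c1` is ethylamino in place of hexyloxy on a carbonyl carbon. Going by the values given here, the single measured step, an at least 1.8-fold higher number from compound 1 to compound 2 (0.25 log units; that floor lies within the scatter), alters a different position and does not bear on this carbonyl substituent; it is anyway close to the scatter. Among the compounds with values here, no measured step informs the direction, so no step beyond the scatter is expected. Compound 4 is estimated at 180000 nM (range 60000 nM to 500000 nM), an expected at least 1.1-fold lower number from compound 3 to compound 4 (0.04 log units; that floor lies within the scatter), most likely again reported as a limit.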

Compound 4, half-maximal inhibitory concentration: 90000 nM
For compound 4 the middle estimate is 2.0-fold (0.30 log units) above the measured one, within the range that was stated.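

Ethylamino in place of hexyloxy on the carbonyl carbon gives an at least 2.2-fold lower number from compound 3 to compound 4 (0.34 log units; beyond the scatter), so this substituent does affect the read-out. Ethylcarbamoyl in place of hydrogen gives an at least 2.2-fold lower number from compound 2 to compound 4 (0.34 log units; beyond the scatter), while ethylcarbamoyl in place of dimethylsulfamoyl gives a 1.2-fold lower number from compound 1 to compound 4 (0.09 log units; within the scatter), leaving those two groups unseparated. The two steps beyond the scatter are floors, not exact sizes: the limit of > 200000 nM in this assay, at which 2 of the 4 values shown sit.

The change from hexyloxy to ethylamino alters the chain and the atom joining it to the carbonyl together, and the two effects remain unseparated. Open too, going by these compounds, is how a hexylamino chain or a carboxylic acid would read at this place.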